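The source may hold more compounds than are shown below. What is called first, only, known or untested is meant among the compounds shown, and "the series" means these compounds.

Series notes, an assay on membranes from brain for binding affinity to Lysophosphatidylserine lipase ABHD12 (Mus musculus), read by fluorescence, with a stated time of 20 min, tested at 10 uM; on this read-out higher numbers stand for a stronger effect at the one concentration tested and lower numbers for a weaker effect. Compound 1 `O=C(Nc1cccnc1)NC1CCN(c2ncc(C(F)(F)F)cc2Cl)CC1` gives 29% and compound 2 `FC(F)(F)c1cnc(N2CCC(NC(=S)Nc3cccnc3)CC2)c(Cl)c1` gives 96%; compound 2 therefore holds the highest number of the two measured, its nearest neighbour being compound 1 by the step of a number 67 percentage points higher from compound 1 to compound 2 (beyond the scatter). Compound 3 `FC(F)(F)c1cnc(N2CCC(NC(=S)Nc3cnc4ccccc4c3)CC2)c(Cl)c1` is the next point and has not yet been run in this assay. Its change from compound 2 is counted as quinolin-3-yl in place of pyridin-3-yl on an amide-type nitrogen. Among the measured compounds shown here, no measured step bears on this change: the single step, from compound 1 to compound 2, alters a different part of the molecule and leaves the pyridin-3-yl in place, so it gives no direct guide. Compound 2 already stands at 96%, close to the top of the read-out, and on that basis the expected step of a number 6 percentage points lower from compound 2 to compound 3 (within the scatter) is small, within the scatter, with little room upward. Compound 3 is estimated at 90%, between 70% and 99%.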

Compound 3, a percentage reported as inhibition, at one concentration (the size of the read-out at that concentration, not a potency): 2%
Compound 3: the middle estimate sits 88 percentage points above what was measured; measured number below the stated range.
By their numbers in this assay, from the lowest: compound 3; then compound 1; then compound 2.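

In this assay, the step of a number 94 percentage points lower from compound 2 to compound 3 (beyond the scatter) comes with quinolin-3-yl in place of pyridin-3-yl on the amide-type nitrogen, so this position, left unchanged in the earlier step, does not accept every aromatic group. The thiocarbonyl alone is also not enough for a high read-out, as compound 3 retains it and still gives 2%. Nothing available accounts for this drop.

The compounds shown leave open whether a smaller addition on the same nitrogen, such as phenyl or a pyridin-3-yl carrying a single methyl, would keep the read-out of compound 2. They also leave open whether the urea of compound 1 would respond to quinolin-3-yl in the same way.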